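Trimming the Amide Substituent to a Small Hydroxyalkyl Group

A few compounds are considered here, and "the series" means these few. Any claim that something is new, unique, unknown or untested is made for them only; others in the source may bear on it.

Measured compounds:
compound 1, `CCn1c(C(=O)N(CCC#N)CCC#N)ccc1C(CC)(CC)c1ccc(OCCC(O)(CC)CC)c(C)c1`: > 50000 nM
compound 2, `CCC(C)C(NC(=O)c1ccc(C(CC)(CC)c2ccc(OCCC(O)(CC)CC)c(C)c2)n1CC)C(=O)OC`: > 50000 nM
compound 3, `CCn1c(C(=O)N(C)CCO)ccc1C(CC)(CC)c1ccc(OCCC(O)(CC)CC)c(C)c1`: 3090 nM

In a functional assay on PC-3 cells (Homo sapiens) for antiproliferative activity, read by MTT assay, with a stated time of 48 h (on this read-out lower numbers stand for stronger inhibition and higher numbers for weaker inhibition), compound 1 gives > 50000 nM, which is a limit of the assay and not a number. Compound 2 likewise gives > 50000 nM, again only a limit. Compound 3 gives 3090 nM, a proper number. Compound 2 therefore stands at the limit, and so does compound 1; both sit at the limit of > 50000 nM in this assay, at which 2 of the 3 values shown sit, so only compound 3 supplies a measured value among the three.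

Compound 4, `CCn1c(C(=O)NC(C)CO)ccc1C(CC)(CC)c1ccc(OCCC(O)(CC)CC)c(C)c1`, differs from compound 2 on the amide-type nitrogen: a group of 4 heavy atoms (3 carbon, 1 oxygen; no ring) in place of a group of 9 heavy atoms (7 carbon, 2 oxygen; no ring), on an amide-type nitrogen. The measured steps that touch this part of the molecule are an at least 16-fold lower number from compound 2 to compound 3 (1.20 log units; beyond the scatter) and an at least 16-fold lower number from compound 1 to compound 3 (1.20 log units; beyond the scatter), both large and both pointing toward lower numbers when a small hydroxy-bearing substituent replaces a bulkier group on the carbonyl carbon, while a step that the two limits leave unreadable from compound 1 to compound 2 cannot be read because both ends are limits.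

Compound 4 carries a 1-(hydroxymethyl)ethyl group, small and hydroxy-bearing like the substituent of compound 3, so a large lowering of the number in this assay is expected for compound 4, roughly an at least 10-fold lower number from compound 2 to compound 4 (1.00 log units; beyond the scatter). Compound 4 is estimated at 5000 nM, with a likely range from 1500 nM to 25000 nM.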

Compound 4, half-maximal inhibitory concentration: 7870 nM
For compound 4 the middle estimate is 1.6-fold (0.20 log units) below the measured one, and the stated range covers the measured number.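

With the 1-(hydroxymethyl)ethyl group on the amide-type nitrogen, a second compound gives a measured number in this assay, with an at least 6.3-fold lower number from compound 2 to compound 4 (0.80 log units; beyond the scatter) and an at least 6.3-fold lower number from compound 1 to compound 4 (0.80 log units; beyond the scatter). Compound 2 and compound 1 each stand at a limit of the assay and not at a number, so these two steps have a readable lower bound only: the limit of > 50000 nM in this assay, at which 2 of the 4 values shown sit.

The new comparison between two measured numbers is a 2.5-fold higher number from compound 3 to compound 4 (0.41 log units; beyond the scatter), which shows that at this carbonyl carbon the two small hydroxy-bearing groups are not interchangeable, since (1-(hydroxymethyl)ethyl)amino and (2-hydroxyethyl)(methyl)amino are separated by a modest step beyond the scatter.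

The compounds shown leave open which part of that replacement carries the step, the branched chain or the loss of the methyl group in favour of the amide hydrogen, and an unbranched 2-hydroxyethyl amide would separate the two. They also leave open whether the hydroxyl itself is required, a question that a 2-methoxyethyl or 2-aminoethyl group in the same place could address.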